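From 3,4-dimethoxyphenyl to 3,5-difluorophenyl on the shared core

The source may hold more compounds than are shown below. What is called first, only, known or untested is meant among the compounds shown, and "the series" means these compounds.

In a functional assay on HT-29 cells (Homo sapiens) for antiproliferative activity, read by sulforhodamine B assay, with a stated time of 48 h (a higher number here means a weaker inhibitor, a lower number a stronger inhibitor), compound 1 (`CCCCN1CCN(c2ccc(S(=O)(=O)Oc3ccccc3)cc2)C1=O`) reaches only a limit of the assay at > 100000 nM and gives no actual number. Compound 2 (`CCCCN1CCN(c2ccc(S(=O)(=O)Oc3cccc(F)c3)cc2)C1=O`) gives 76000 nM and compound 3 (`CCCCN1CCN(c2ccc(S(=O)(=O)Oc3ccc(OC)c(OC)c3)cc2)C1=O`) gives 21000 nM as the lower of the two actual numbers. Compound 4 (`CCCCN1CCN(c2ccc(S(=O)(=O)Oc3cc(F)cc(F)c3)cc2)C1=O`) has 3,5-difluorophenyl in place of 3,4-dimethoxyphenyl on an oxygen whose other neighbour is the sulfonyl sulfur (3,5-difluorophenyl in place of 3,4-dimethoxyphenyl on an oxygen). Within the data shown here, three measured steps bear on this change. Among the measured compounds shown here, the closest is a 3.6-fold lower number from compound 2 to compound 3 (0.56 log units; beyond the scatter) and it links compound 3 to the only measured compound carrying fluoro. Adding fluoro gave an at least 1.3-fold lower number from compound 1 to compound 2 (0.11 log units; that floor lies within the scatter) and so shows little, while the dimethoxy change gave an at least 4.7-fold lower number from compound 1 to compound 3 (0.67 log units; beyond the scatter) as its measured gain. Compound 4 therefore looks more like compound 2 (76000 nM) than compound 3 in this series. The expected change is a 2.4-fold higher number from compound 3 to compound 4 (0.38 log units; beyond the scatter) in this assay as a modest move towards weaker inhibition. Compound 4 is estimated at 50000 nM (expected range 20000 nM to 100000 nM).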

Compound 4, half-maximal inhibitory concentration: > 100000 nM
Compound 4 was reported as a limit (the forecaster's own chance of this, stated with the estimate: 20%); at least 2.0-fold (0.30 log units) between middle value and limit.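

The change on the oxygen whose other neighbour is the sulfonyl sulfur gives up what 3,4-dimethoxyphenyl had gained, with an at least 4.7-fold higher number from compound 3 to compound 4 (0.67 log units; beyond the scatter) in this assay. Compound 4 gives > 100000 nM, which is a limit of the assay and not a number. The added fluoro gives an at least 1.3-fold higher number from compound 2 to compound 4 (0.11 log units; that floor lies within the scatter), so it shows no readable effect, and the step between compound 1 and compound 4 cannot be read, both values being limits: the limit of > 100000 nM in this assay, at which 2 of the 4 values shown sit.

The compounds shown leave open whether a single methoxy group would carry the gain seen with 3,4-dimethoxyphenyl or whether both are needed. They also leave open how an amine or a carboxylic acid on this aromatic ring would read in this assay.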